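Pyridin-3-yl in place of 4-methylphenyl: compound 3

The source may report more compounds than this note shows. Statements on the series, on what has been measured and on what is new or still open speak of the compounds shown alone.

For the measured compounds named here, compound 2 `COc1cc(C(F)(F)F)cc(SC)c1C(=O)NC1(c2ccc(C)cc2)CCCN(C)C1` is the only compound with a number in an assay on cells for inhibition of sodium- and chloride-dependent glycine transporter 1 (Homo sapiens) (on this read-out lower numbers stand for an effect already at smaller amounts and higher numbers for an effect only at larger amounts of compound), where compound 2 gives 230 nM. Compound 1 `CN1CCCC(NC(=O)c2ccc(C(F)(F)F)cc2)(c2ccccc2)C1` gives only a limit in this assay, namely > 10000 nM, which is the limit of > 10000 nM in this assay, at which 1 of the 2 values shown sits. Compound 3 `COc1cc(C(F)(F)F)cc(SC)c1C(=O)NC1(c2cccnc2)CCCN(C)C1` differs from compound 2 by pyridin-3-yl in place of 4-methylphenyl on a saturated ring carbon. Going by the values given here, no step between measured compounds bears on this change. A shift to a higher number in this assay is expected, somewhat beyond the usual scatter, as a 3.0-fold higher number from compound 2 to compound 3 (0.48 log units; beyond the scatter). Compound 3 is estimated at 700 nM, within a range from 180 nM to 2800 nM.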

Compound 3, half-maximal effective concentration: 54 nM
For compound 3 the middle estimate is 13-fold (1.11 log units) above the measured one; the measured number lies below the stated range.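

In this assay the saturated ring carbon two ring bonds from the ring nitrogen accepts pyridin-3-yl in place of 4-methylphenyl, with a 4.3-fold lower number from compound 2 to compound 3 (0.63 log units; beyond the scatter) beyond the scatter. The 4-methylphenyl group is therefore not required at this position, and an aromatic ring with a hetero atom is tolerated there. Nothing available accounts for the size of this step.

From the compounds shown here alone, whether the step follows the ring nitrogen or the loss of the methyl group stays open; a plain phenyl on this carbon would separate the two. Going by these compounds, how pyridin-2-yl or pyridin-4-yl compares also stays open.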